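Compound 3 to compound 4: methoxy in place of methyl

The source may report more compounds than this note shows. Statements on the series, on what has been measured and on what is new or still open speak of the compounds shown alone.

In a functional assay on L1210 cells (Mus musculus) for antiproliferative activity, read by cell counting, with a stated time of 2 days (a higher number here means a weaker inhibitor, a lower number a stronger inhibitor), compound 1 `COc1cc(C(=O)c2sc(Nc3ccccc3)nc2N)cc(OC)c1OC` gives 18 nM, compound 2 `COc1ccc(Nc2nc(N)c(C(=O)c3ccc(OC)c(OC)c3)s2)cc1` gives 38 nM and compound 3 `COc1cc(C(=O)c2sc(Nc3ccc(C)cc3)nc2N)cc(OC)c1OC` gives 31 nM. Compound 3 lies within the scatter of both other compounds. Compound 4 `COc1ccc(Nc2nc(N)c(C(=O)c3cc(OC)c(OC)c(OC)c3)s2)cc1` has methoxy in place of methyl on an aromatic carbon, para to a large group: methoxy in place of methyl on an aromatic carbon. Among the compounds with values here, the one measured step on that carbon, a 1.7-fold higher number from compound 1 to compound 3 (0.24 log units; within the scatter), methyl in place of hydrogen, stays within the scatter. Compound 2 already carries the (4-methoxyphenyl)amino group but differs from compound 4 elsewhere, so it is only a loose guide. No change beyond the scatter is expected in this assay, and no direction is favoured; the expected step is a 1.1-fold lower number from compound 3 to compound 4 (0.04 log units; within the scatter). Compound 4 is estimated at 28 nM, with an expected range of 12 nM to 60 nM.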

Compound 4, half-maximal inhibitory concentration: 1500 nM
The estimate for compound 4 lay 54-fold (1.73 log units) below the measured number, and the stated range ends below it.
By their numbers in this assay, from the lowest: compounds 1, 3 and 2 (each within the scatter of the next, the first and the last beyond it); then compound 4.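

Methyl on this aromatic carbon stayed within the scatter, but methoxy there gives a far larger change: a 48-fold higher number from compound 3 to compound 4 (1.68 log units; beyond the scatter) and an 83-fold higher number from compound 1 to compound 4 (1.92 log units; beyond the scatter). The (4-methoxyphenyl)amino group alone does not carry this loss, since compound 2 has it too, and methoxy in place of hydrogen on another aromatic carbon still gives a 39-fold higher number from compound 2 to compound 4 (1.60 log units; beyond the scatter). The loss thus appears here only with both methoxy changes together, and no measurement available bears on its cause.

As far as these compounds go, whether an amine or a hydroxyl on the same carbon behaves like methoxy stays open. So does whether a longer chain such as ethoxy does.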